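Aryl Amide Variation on a Naphthyl Hexafluoro-carbinol Core

A few compounds are considered here, and "the series" means these few. Any claim that something is new, unique, unknown or untested is made for them only; others in the source may bear on it.

The compounds measured so far:
compound 1, `CCC(C)C(=O)Nc1c(C(O)(C(F)(F)F)C(F)(F)F)ccc2ccccc12`, 177000 nM;
compound 2, `CCCC(C)C(=O)Nc1c(C(O)(C(F)(F)F)C(F)(F)F)ccc2ccccc12`;
compound 3, `Cc1ccccc1C(=O)Nc1c(C(O)(C(F)(F)F)C(F)(F)F)ccc2ccccc12`, 5550 nM.

In an assay on LtK cells with ATP-sensitive inward rectifier potassium channel 11 (Homo sapiens) as the target (on this read-out lower numbers stand for an effect already at smaller amounts and higher numbers for an effect only at larger amounts of compound), compound 2 gives only a limit, > 10000 nM, and no number. Compound 3 stands at the lowest of the two numbers shown: a 32-fold lower number from compound 1 to compound 3 (1.50 log units; beyond the scatter), while the comparison with compound 2 reads an at least 1.8-fold lower number from compound 2 to compound 3 (0.25 log units; that floor lies within the scatter). Within the data shown here, both steps replace a saturated chain on the carbonyl carbon with an aryl group, and the one readable step is large.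

Compound 4, `O=C(Nc1c(C(O)(C(F)(F)F)C(F)(F)F)ccc2ccccc12)c1ccc(F)cc1`, keeps the aryl amide but alters the ring substituent: 4-fluorophenyl in place of 2-methylphenyl on a carbonyl carbon. Among the measured compounds shown here, no measured step changes one aryl group for another, so the steps from compound 1 and compound 2 to compound 3 show only that an aryl amide outperforms the chains; they do not say how the fluorine position will compare with the methyl. Compound 4 is therefore expected to stay within the scatter of compound 3, with the step of a 1.1-fold higher number from compound 3 to compound 4 (0.03 log units; within the scatter) being small in either direction. Compound 4 is estimated at 6000 nM in this assay, in the range 2000 nM to 20000 nM.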

Compound 4, half-maximal effective concentration: 70 nM
Estimate against measurement, compound 4: 86-fold (1.93 log units) above, outside the stated range (below it).
By their numbers in this assay, from the lowest: compound 4; then compound 3; then compound 1.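

Compound 4 shows that in this assay the group on the carbonyl carbon matters beyond being an aryl group at all: exchanging one aryl group for another, with the heavy-atom count unchanged, gives a 79-fold lower number from compound 3 to compound 4 (1.90 log units; beyond the scatter). Against the saturated chains, the same position spans a 2500-fold lower number from compound 1 to compound 4 (3.40 log units; beyond the scatter), so the earlier contrast between chain and aryl group was only part of what this place can show. Compound 2 gives only a limit, and an at least 140-fold lower number from compound 2 to compound 4 (2.15 log units; beyond the scatter) is therefore a floor and not a measured size: the limit of > 10000 nM in this assay, at which 1 of the 4 values shown sits.

The compounds shown leave open whether the step belongs to the loss of the methyl, the arrival of the fluorine, or the different placing of the substituent, and a plain phenyl, a 4-methylphenyl or a 2-fluorophenyl on the carbonyl carbon would separate these. Going by these compounds, it also remains open whether the fluorine itself is needed, as 4-chlorophenyl or 4-methoxyphenyl at this position would show, and how the shared core responds to change while the 4-fluorophenyl stays in place.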